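Amino substituent swap on the shared core: toward compound 3

The compounds below may be only part of what the source reports. "The series", "measured", "known", "first", "only" and "open" are said of these compounds alone.

Measured so far in a functional assay on SV5A8 cells (Homo sapiens) for cytotoxicity; a higher number here means a weaker inhibitor, a lower number a stronger inhibitor:
compound 1, `Cc1ccc2c(NCc3ccc(NC(=O)C4CCN(Cc5ccccc5)CC4)cc3)nc(N3CCCCCC3)nc2c1`: > 6880 nM
compound 2, `Cc1ccc2c(NCc3ccc(NC(=O)C4CCN(Cc5cc(Cl)ccn5)CC4)cc3)nc(N(C)C)nc2c1`: > 5400 nM

The value for compound 1 in this assay is a limit of the assay and not a number (the limit of > 6880 nM in this assay, at which 1 of the 2 values shown sits). The value for compound 2 in this assay is likewise a limit (the limit of > 5400 nM in this assay, at which 1 of the 2 values shown sits). With both results sitting at limits, neither compound can be placed above or below the other; all that is known is that compound 1 reaches no measurable inhibition within the tested range.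

Compound 3, `Cc1ccc2c(NCc3ccc(NC(=O)C4CCN(Cc5ccccc5)CC4)cc3)nc(N(C)CCCN(C)C)nc2c1`, is still to be measured. It differs from compound 1 in one place: (3-(dimethylamino)propyl)(methyl)amino in place of azepan-1-yl on an aromatic carbon. Among the compounds with values here, no step between measured compounds exists to calibrate this change, and the starting point itself is only a limit, so the size and direction of the step are open.

The expectation is that compound 3 will also show little inhibition, giving an estimated step that the limit leaves unreadable from compound 1 to compound 3 in this assay. Compound 3 is therefore estimated at 7000 nM, within a range from 2000 nM to 30000 nM, with a fair chance that only a limit is reported again.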

Compound 3, half-maximal inhibitory concentration: > 8620 nM
Compound 3 ended at the assay's limit (the forecaster's own chance of this, stated with the estimate: 65%); middle value at least 1.2-fold (0.09 log units) from the limit.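

In this assay compound 3 gives > 8620 nM, which is a limit of the assay and not a number. Compound 1 gives > 6880 nM, likewise a limit. Within the data shown here, no step between compound 1 and compound 3 can be read from these two limits. Whether (3-(dimethylamino)propyl)(methyl)amino in place of azepan-1-yl changes inhibition at all stays open, as no compound shown gives a number in this assay.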